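A few compounds are considered here, and "the series" means these few. Any claim that something is new, unique, unknown or untested is made for them only; others in the source may bear on it.

Measured so far:
compound 1, `COc1ccc(/C=N/NC(=O)COc2cccc3ccccc23)cc1O`, 100 ug/mL
compound 2, `C/C(=N\NC(=O)COc1cccc2ccccc12)c1ccccc1`, 20 ug/mL

In an ADME assay on HEL cells (Homo sapiens) for cytotoxicity (on this read-out higher numbers stand for lower toxicity in this test and lower numbers for higher toxicity in this test), compound 1 gives 100 ug/mL, while compound 2 gives 20 ug/mL. Compound 2 thus stands at the lower of the two numbers, and its gap to compound 1 lies beyond the usual scatter of this assay. Compound 3, `C/C(=N\NC(=O)COc1cccc2ccccc12)c1ccc(Br)cc1`, has not yet been tested in this assay. It differs from compound 2 in one place: bromo in place of hydrogen on an aromatic carbon. The bromo group enters on an aromatic carbon of a six-membered aromatic ring of carbon only, so that, read one bond further out, phenyl becomes 4-bromophenyl. No two measured compounds differ in just this way, so this step has no precedent among the numbers shown. The expected step in this assay is small, with no clear direction beyond the scatter: no change at the digits printed from compound 2 to compound 3 (within the scatter). Compound 3 is accordingly estimated at 20 ug/mL, within a range from 4 ug/mL to 100 ug/mL.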

Compound 3, minimum cytotoxic concentration: 20 ug/mL
Estimate against measurement, compound 3: no gap at the digits printed; measured number inside the range.
By their numbers in this assay, from the lowest: compounds 2 and 3 (each within the scatter of the next); then compound 1.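

In this assay, putting bromo in place of hydrogen on an aromatic carbon, para to a large group, turns phenyl into 4-bromophenyl and gives no change at the digits printed from compound 2 to compound 3 (within the scatter), the first step of its kind among these compounds. It shows that, in this test, this position of compound 2 accepts a single bromine atom with the read-out staying within the scatter. No measurement at hand accounts for this result.

The compounds shown leave open whether a group of another kind at this same position, such as an amine, a carboxylic acid or a longer chain, would also stay within the scatter of compound 2. They also leave open whether bromo would behave in the same way on another carbon of this ring or on a different core.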